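The compounds below may be only part of what the source reports. "The series", "measured", "known", "first", "only" and "open" are said of these compounds alone.

Working notes on the series, measured in an ADME assay on cells (Hepatocyte, Rattus norvegicus, strain Wistar) for pharmacokinetics, read by LC-MS, with a stated time of 90 min, tested at 1 uM; a lower number here means slower removal, a higher number faster removal of the compound:

- compound 1 `CCCN(CC1CCOC1)C(=O)c1cc(OC)c2oc(NCc3cccc(Cl)c3)nc2c1`: 65 mL/min/kg
- compound 2 `COc1cc(C(=O)N2CC[C@@H](O)[C@H](C)C2)cc2nc(NCc3cccc(Cl)c3)oc12`: 38.3 mL/min/kg
- compound 3 `COc1cc(C(=O)N2CCC(O)C(C)C2)cc2nc(NC3(c4cccc(Cl)c4)CC3)oc12`: 46.7 mL/min/kg

Compound 2 has the smallest number of the three, but that position carries little weight. At 38.3 mL/min/kg, compound 2 stands within the usual scatter of both other compounds, so none of the three can be separated from it in this assay.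

Next in line is compound 4 `COc1cc(C(=O)N2CC(C)C(O)CC2C2CC2)cc2nc(NCc3cccc(Cl)c3)oc12`, not yet measured. The change from compound 2 is 2-cyclopropyl-4-hydroxy-5-methylpiperidin-1-yl in place of 4-hydroxy-3-methylpiperidin-1-yl on a carbonyl carbon. In words, 2-cyclopropyl-4-hydroxy-5-methylpiperidin-1-yl comes in place of 4-hydroxy-3-methylpiperidin-1-yl on a carbonyl carbon.

Among the compounds with values here, only one measured step touches this place: a 1.7-fold lower number from compound 1 to compound 2 (0.23 log units; within the scatter). That step swapped a whole amide substituent and still did not clear the scatter. Within the data shown here, no measured pair shows what a cyclopropyl group adds to this piperidine, so the data give no direction for the new step with any confidence. A step beyond the scatter is therefore not expected, and the wide range reflects this lack of a direct precedent.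

The expected change is a 1.2-fold higher number from compound 2 to compound 4 (0.07 log units; within the scatter), estimated to stay within the scatter. For compound 4 the estimated clearance is 45 mL/min/kg, with an expected range of 25 mL/min/kg to 75 mL/min/kg.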

Compound 4, clearance: 63.3 mL/min/kg
Compound 4: middle estimate off by 1.4-fold (0.15 log units), on the low side, within the range that was stated.
By their numbers in this assay, from the lowest: compounds 2, 3, 4 and 1 (each within the scatter of the next).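

In this assay, within the data shown here, compound 4 gives the first direct reading of a cyclopropyl group on this piperidine, attached through its nitrogen to a carbonyl carbon, and the result is a 1.7-fold higher number from compound 2 to compound 4 (0.22 log units; within the scatter). The step to 2-cyclopropyl-4-hydroxy-5-methylpiperidin-1-yl therefore cannot be told apart from no change, and the same holds for the comparison with the ((oxolan-3-yl)methyl)(propyl)amino amide, at a 1.0-fold lower number from compound 1 to compound 4 (0.01 log units; within the scatter); so far, none of the three groups shown on this carbonyl carbon separates from another in this assay. No supporting data bear on this result, so the reading stays purely descriptive.

Still open, going by these compounds, is whether a different substituent in place of the cyclopropyl group, such as a longer chain like n-butyl, or a primary amine or carboxylic acid on the piperidine, would give a step beyond the scatter. Also open, on these data alone, is how single stereoisomers of the group in compound 4 would compare, given that this group carries no defined stereocentres while the group in compound 2 carries two.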